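This account rests on a few compounds, and the source may have more. Where it says the series, first, only, none or still open, it means among the compounds named here.

Measured in a functional assay on MCF7 cells (Homo sapiens) for cytotoxicity, read by MTT assay, with a stated time of 96 h; a lower number here means a stronger inhibitor, a higher number a weaker inhibitor:
Compound 1 `COc1cc(C(=O)c2cn(-c3ccc(N)cc3)cc2-c2ccccc2)cc(OC)c1OC`: 35 nM
Compound 2 `COc1ccc(-n2cc(C(=O)c3cc(OC)c(OC)c(OC)c3)c(-c3ccccc3)c2)cc1`: 120 nM

Compound 1 holds the lower of the two numbers. Compound 3 `COc1cc(C(=O)c2cn(-c3ccc(N)cc3)cc2-c2ccccc2Cl)cc(OC)c1OC` has chloro in place of hydrogen on an aromatic carbon, phenyl to 2-chlorophenyl, ortho to a large group: chloro in place of hydrogen on an aromatic carbon. Going by the values given here, the only measured step is a 3.4-fold higher number from compound 1 to compound 2 (0.54 log units; beyond the scatter), a modest one for methoxy in place of amino. Among the compounds with values here, no measured step changes the phenyl, so that step is only a rough guide to size, and the direction is uncertain. A modest rise in this assay is expected: a 1.4-fold higher number from compound 1 to compound 3 (0.15 log units; within the scatter). For compound 3 the estimate is 50 nM, with an expected range of 12 nM to 200 nM.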

Compound 3, half-maximal inhibitory concentration: 83 nM
Beside the measured number, compound 3's estimate is 1.7-fold (0.22 log units) below it, and the stated range covers the measured number.
By their numbers in this assay, from the lowest: compound 1; then compounds 3 and 2 (each within the scatter of the next).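

Chloro in place of hydrogen, ortho to a large group, gives the first measured change on the phenyl: in this assay the step is a 2.4-fold higher number from compound 1 to compound 3 (0.38 log units; beyond the scatter), a modest rise in the number. This place on the phenyl therefore tolerates chloro with the number still in the nanomolar range, though the change does not lower it. No available evidence bears on the reason for this rise.

As far as these compounds go, whether fluoro, methyl or methoxy at this place would give a similar step remains open. Also open, from the compounds shown here alone, is whether chloro gives the same step when methoxy replaces the amino group.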